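Swapping 2-hydroxy-2-methylpropyl for isopropyl on compound 2

The compounds below may be only part of what the source reports. "The series", "measured", "known", "first", "only" and "open" are said of these compounds alone.

Values in a functional assay on MDA-MB-231 cells (Homo sapiens) for inhibition, read by MTT assay, with a stated time of 5 days (on this read-out lower numbers stand for stronger inhibition and higher numbers for weaker inhibition), so far:
compound 1 `Cc1cc(Nc2nc(NCc3ccc(Cl)cc3)nc3c2cnn3C(C)C)n[nH]1` gives 4860 nM
compound 2 `Cc1cc(Nc2nc(NCc3ccc(F)cc3F)nc3c2cnn3CC(C)(C)O)n[nH]1` gives 2510 nM

Compound 2 stands within the scatter of compound 1, so the two values set no order. Compound 3 `Cc1cc(Nc2nc(NCc3ccc(F)cc3F)nc3c2cnn3C(C)C)n[nH]1` has isopropyl in place of 2-hydroxy-2-methylpropyl on an aromatic nitrogen relative to compound 2. Among the measured compounds shown here, no measured step isolates this change. Compound 1 also carries isopropyl and gives 4860 nM in this assay, close to compound 2 within the scatter. The expected move is small, with no firm direction and nothing beyond the scatter: a 1.2-fold higher number from compound 2 to compound 3 (0.08 log units; within the scatter) is estimated. For compound 3 the estimate is 3000 nM, with an expected range from 1100 nM to 8000 nM.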

Compound 3, half-maximal inhibitory concentration: 5350 nM
For compound 3 the middle estimate is 1.8-fold (0.25 log units) below the measured one, within the range that was stated.
By their numbers in this assay, from the lowest: compounds 2, 1 and 3 (each within the scatter of the next, the first and the last beyond it).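

On the aromatic nitrogen in this assay, isopropyl in place of 2-hydroxy-2-methylpropyl gives a 2.1-fold higher number from compound 2 to compound 3 (0.33 log units; beyond the scatter) and so gives this position its first reading, a modest step just beyond the scatter. At the other site, 2,4-difluorophenyl in place of 4-chlorophenyl gives a 1.1-fold higher number from compound 1 to compound 3 (0.04 log units; within the scatter) and sets no order between those two groups. No measurement here offers a cause for either step. From the compounds shown here alone, whether the step follows the hydroxyl or the longer chain stays open, and isobutyl on the same nitrogen would separate the two.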